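The source may hold more compounds than are shown below. What is called first, only, known or untested is meant among the compounds shown, and "the series" means these compounds.

Measured so far in a functional assay (mast cells) for inhibition, with Rattus norvegicus as the target; a higher number here means that more compound is needed for the effect, a lower number that less compound is needed:
- compound 1 `Cc1ccc(N/N=C2\CCC(C)n3c2ncc(C(=O)O)c3=O)cc1`: 280 nM
- compound 2 `CC1CC/C(=N\Nc2ccc(C(=O)O)cc2)c2ncc(C(=O)O)c(=O)n21`: 1000000 nM

Within the data shown here, of these two numbers, the one for compound 2 is the higher, and the gap lies well beyond the scatter. Compound 3 `CC(C)c1ccc(N/N=C2\CCC(C)n3c2ncc(C(=O)O)c3=O)cc1` has not yet been measured. It differs from compound 2 by isopropyl in place of carboxy on an aromatic carbon, para to a large group: isopropyl in place of carboxy on an aromatic carbon.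

Among the measured compounds shown here, one measured step bears on this change: a 3600-fold higher number from compound 1 to compound 2 (3.55 log units; beyond the scatter), a large step that came with carboxy in place of methyl at that same place. Compound 3 loses that carboxy again, but it carries isopropyl where compound 1 carries methyl, and no measurement shows what that exchange does. Most of the large step is therefore expected to reverse, towards a much lower number in this assay, though with wide uncertainty. The expected change is a 2500-fold lower number from compound 2 to compound 3 (3.40 log units; beyond the scatter). For compound 3 the estimate is 400 nM, with an expected range from 80 nM to 3000 nM.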

Compound 3, half-maximal effective concentration: 1200 nM
Estimate against measurement, compound 3: 3.0-fold (0.48 log units) below; the range from low to high includes it.
By their numbers in this assay, from the lowest: compound 1; then compound 3; then compound 2.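

In this assay, the new result shows that the very high number of compound 2 depends on the carboxy at this place, para to a large group: exchanging it for isopropyl gives an 830-fold lower number from compound 2 to compound 3 (2.92 log units; beyond the scatter) and so takes back most of the large step that the carboxy had brought. It also shows that this place accepts isopropyl as well as methyl with only a limited cost, since the exchange of methyl for isopropyl gives a 4.3-fold higher number from compound 1 to compound 3 (0.63 log units; beyond the scatter) and stays modest, though beyond the scatter. Nothing at hand explains why either step has the size it has.

With only methyl and isopropyl as the alkyl groups here, the compounds shown set no trend with chain size, and they leave open whether a tert-butyl group or a longer chain such as n-butyl would raise the number further. They also leave open whether the high number belongs to the carboxylic acid alone or would return with an amine, a methyl ester or a methoxy group at this place.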